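Notes on compound 4: the bare acid end of the series

The source may hold more compounds than are shown below. What is called first, only, known or untested is meant among the compounds shown, and "the series" means these compounds.

Three acids share one core and differ only at the saturated chain carbon three bonds along the chain from a double-bonded chain carbon. Compound 1 `C=C(C)C(CCC/C=C(\c1ccccc1)c1cccnc1)C(=O)O` gives 28 nM in an assay (Equus caballus) for inhibition of Thromboxane-A synthase (Homo sapiens), using microsomes; a lower number here means a stronger inhibitor, a higher number a weaker inhibitor; compound 2 `CC(C)(CCC/C=C(\c1ccccc1)c1cccnc1)C(=O)O` gives 21 nM; compound 3 `COCC(CCC/C=C(\c1ccccc1)c1cccnc1)C(=O)O` gives 41 nM. Compound 3 has the highest of the three numbers, but the steps leading to it are small: a 1.5-fold higher number from compound 1 to compound 3 (0.17 log units; within the scatter) and a 2.0-fold higher number from compound 2 to compound 3 (0.29 log units; within the scatter), both within the scatter, as is a 1.3-fold lower number from compound 1 to compound 2 (0.12 log units; within the scatter). Compound 4 `O=C(O)CCC/C=C(\c1ccccc1)c1cccnc1` cuts this position back to the bare acid: carboxy in place of 1-carboxy-2-methoxyethyl on a saturated chain carbon, three bonds along the chain from a double-bonded chain carbon. Among the compounds with values here, no measured step removes the whole side group; the three steps that bear on it only exchange one group for another at the same carbon, and none of them moved the number beyond the scatter. The expectation for compound 4 in this assay is therefore a step of about a 1.1-fold higher number from compound 3 to compound 4 (0.04 log units; within the scatter), with no firm direction and wider uncertainty than between the measured pairs. Compound 4 is estimated at 45 nM, with an expected range from 15 nM to 140 nM.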

Compound 4, half-maximal inhibitory concentration: 30 nM
Compound 4: middle estimate off by 1.5-fold (0.18 log units), on the high side, within the range that was stated.
By their numbers in this assay, from the lowest: compounds 2, 1, 4 and 3 (each within the scatter of the next).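

Earlier steps only exchanged one group for another at this carbon; the new steps cut the side group back to carboxy, and in this assay they read as a 1.4-fold lower number from compound 3 to compound 4 (0.14 log units; within the scatter) and as a 1.4-fold higher number from compound 2 to compound 4 (0.15 log units; within the scatter) and as a 1.1-fold higher number from compound 1 to compound 4 (0.03 log units; within the scatter). Across the compounds shown, then, the number with the bare acid cannot be told apart from the number with any of the three larger groups, so this position tolerates losing the whole side group as well as exchanging it. Nothing available explains this flatness.

As far as these compounds go, all four compounds keep the carboxylic acid, so whether an amine or an amide in its place would leave the number as flat remains open. From the compounds shown here alone, whether a longer chain between the acid and the double-bonded chain carbon would do the same is also open.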